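The source may report more compounds than this note shows. Statements on the series, on what has been measured and on what is new or still open speak of the compounds shown alone.

Measured in a functional assay on LOX IMVI cells (Homo sapiens) for cytotoxicity, read by MTT assay, with a stated time of 24 h; on this read-out higher numbers stand for weaker inhibition and lower numbers for stronger inhibition:
- compound 1 `COc1cc(-c2nc(-c3ccccc3)[nH]c2-c2ccnc(NCCCNS(=O)(=O)c3ccc(Br)cc3)n2)ccc1Cl` gives 23700 nM
- compound 2 `COc1cc(-c2nc(-c3ccccc3)[nH]c2-c2ccnc(NCCCNS(=O)(=O)c3ccc(F)cc3)n2)ccc1Cl` gives 4530 nM
- compound 3 `COc1cc(-c2nc(-c3ccccc3)[nH]c2-c2ccnc(NCCCNS(=O)(=O)c3ccc(C(F)(F)F)cc3)n2)ccc1Cl` gives 1780 nM

Compound 3 has the lowest number of the three, and its gaps to compound 1 and compound 2 both lie beyond the scatter. The next compound is compound 4 `COc1cc(-c2nc(-c3ccccc3)[nH]c2-c2ccnc(NCCCNS(=O)(=O)c3cccc(F)c3)n2)ccc1Cl`, which differs from compound 3 as follows: 3-fluorophenyl in place of 4-(trifluoromethyl)phenyl on a sulfonyl sulfur. In words, this is 3-fluorophenyl in place of 4-(trifluoromethyl)phenyl on a sulfonyl sulfur.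

The closest measured change is a 2.5-fold lower number from compound 2 to compound 3 (0.41 log units; beyond the scatter), with trifluoromethyl in place of fluoro on an aromatic carbon. That step is modest, and running it backwards points to a higher number once the trifluoromethyl group is gone. The other two steps, a 5.2-fold lower number from compound 1 to compound 2 (0.72 log units; beyond the scatter) and a 13-fold lower number from compound 1 to compound 3 (1.12 log units; beyond the scatter), are modest and large, so a change on this ring can move the number considerably. Going by the values given here, no measured compound carries the 3-fluorophenyl group, so that placement of the fluoro group is untested and the range stays wide.

A modest rise is therefore expected in this assay, close in size to the step separating compound 2 from compound 3. The estimated change is a 2.4-fold higher number from compound 3 to compound 4 (0.37 log units; beyond the scatter). For compound 4 the estimated value is 4200 nM, with an expected range from 1500 nM to 12000 nM.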

Compound 4, half-maximal inhibitory concentration: 5110 nM
The estimate for compound 4 lay 1.2-fold (0.09 log units) below the measured number; low and high end bracket the measured number.
By their numbers in this assay, from the lowest: compound 3; then compounds 2 and 4 (each within the scatter of the next); then compound 1.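

In this assay, the group on the sulfonyl sulfur now varies in where the fluoro sits as well as in which substituent it carries, and the placement gives no readable difference (a 1.1-fold higher number from compound 2 to compound 4 (0.05 log units; within the scatter)), so 3-fluorophenyl and 4-fluorophenyl cannot be told apart in this pair. Going by these compounds alone, both fluoro compounds remain separated from the other two: 4-(trifluoromethyl)phenyl keeps its advantage over the new group (a 2.9-fold higher number from compound 3 to compound 4 (0.46 log units; beyond the scatter)), and 3-fluorophenyl retains a clear lead over 4-bromophenyl (a 4.6-fold lower number from compound 1 to compound 4 (0.67 log units; beyond the scatter)), so across these four compounds the choice of substituent moves the number while the single placement change does not. No measured information is available on the origin of these differences.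

Whether placement is equally silent for other substituents rests on this one fluoro pair, and 3-(trifluoromethyl)phenyl and 3-bromophenyl would test it directly against compound 3 and compound 1. Also open, going by these compounds, are an amine or a carboxylic acid on this aromatic ring, and a longer chain in place of the one carrying the sulfonamide nitrogen.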